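Ketone aryl group exchange: chloro to methylsulfanyl, compound 4

The source may report more compounds than this note shows. Statements on the series, on what has been measured and on what is new or still open speak of the compounds shown alone.

Measured so far in a functional assay on MDA-MB-231 cells (Homo sapiens) for cytotoxicity, read by MTT assay, with a stated time of 48 h; on this read-out higher numbers stand for weaker inhibition and lower numbers for stronger inhibition:
compound 1, `O=C(/C=C/c1ccc2c(c1)B(O)OC2)c1cccnc1`, 11400 nM
compound 2, `Cn1cccc1C(=O)/C=C/c1ccc2c(c1)B(O)OC2`, limit > 100000 nM
compound 3, `O=C(/C=C/c1ccc2c(c1)B(O)OC2)c1ccc(Cl)cc1`, 7900 nM

Compound 2 reports only a limit in this assay, (the limit of > 100000 nM in this assay, at which 1 of the 3 values shown sits). Compound 3 and compound 1 sit within the scatter of each other, a 1.4-fold lower number from compound 1 to compound 3 (0.16 log units; within the scatter), so no order between them is claimed. The step from the pyrrolyl ketone to the chlorophenyl ketone is large, an at least 12-fold lower number from compound 2 to compound 3 (1.10 log units; beyond the scatter), and the pyridinyl-to-pyrrolyl step is at least modest, an at least 8.7-fold higher number from compound 1 to compound 2 (0.94 log units; beyond the scatter).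

Compound 4, `CSc1ccc(C(=O)/C=C/c2ccc3c(c2)B(O)OC3)cc1`, differs from compound 3 in one place: methylsulfanyl in place of chloro on an aromatic carbon. Going by the values given here, no measured step changes a substituent on the six-membered carbon ring of the ketone; the measured steps all exchange the whole aryl group, and the only one that keeps a six-membered ring of carbon in play, a 1.4-fold lower number from compound 1 to compound 3 (0.16 log units; within the scatter), is within the scatter. The beyond-scatter steps both involve the pyrrolyl ketone of compound 2, which compound 4 does not resemble.

Expected, therefore: a step in this assay within the scatter, direction open. Compound 4 is estimated at 7000 nM, between 2800 nM and 18000 nM. The expected step is a 1.1-fold lower number from compound 3 to compound 4 (0.05 log units; within the scatter).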

Compound 4, half-maximal inhibitory concentration: 9800 nM
Beside the measured number, compound 4's estimate is 1.4-fold (0.15 log units) below it, within the range that was stated.
By their numbers in this assay, from the lowest: compounds 3, 4 and 1 (each within the scatter of the next). At a limit, above all of these: compound 2.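

Working notes: the change of a 1.2-fold higher number from compound 3 to compound 4 (0.09 log units; within the scatter) in this assay is the first measured step that alters a substituent on the six-membered carbon ring of the ketone and keeps the rest of the aryl group. On an aromatic carbon para to a large group, this read-out does not separate chloro, with 1 heavy atom and 0 hydrogen-bond acceptors, from methylsulfanyl, with 2 heavy atoms and 1 hydrogen-bond acceptor, so this exchange leaves the number within the scatter, a finding that the whole-group exchanges could not give. Nothing measured on these compounds bears on why these two groups give numbers within the scatter of each other.

Still open, on these data alone, is whether this place tolerates substituents of a different kind, such as an amine or a carboxylic acid on the same aromatic carbon, or a longer chain such as butylsulfanyl in place of methylsulfanyl. A single pair of substituents fixes no trend for this position, and the compounds shown do not tell whether the same exchange would read the same way on another aryl ketone of the series.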